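A few compounds are considered here, and "the series" means these few. Any claim that something is new, unique, unknown or untested is made for them only; others in the source may bear on it.

Compounds measured so far:
- compound 1 `Oc1cccc(-c2cc(-c3ccoc3)cc(-c3cccc(O)c3)n2)c1`: 1650 nM
- compound 2 `Oc1ccc(-c2cc(-c3ccoc3)cc(-c3cccc(O)c3)n2)cc1`: 2700 nM
- compound 3 `Oc1cccc(-c2cc(-c3cccnc3)cc(-c3cccc(O)c3)n2)c1`: not yet measured

In a functional assay on DU-145 cells (Homo sapiens) for cytotoxicity, read by CCK-8 assay (on this read-out higher numbers stand for weaker inhibition and lower numbers for stronger inhibition), compound 1 gives 1650 nM, the lowest of the two numbers available. Among the measured compounds shown here, its nearest neighbour is compound 2, and the only measured step, a 1.6-fold higher number from compound 1 to compound 2 (0.21 log units; within the scatter), lies within the usual scatter. Compound 3 differs from compound 1 by a change at a different position: pyridin-3-yl in place of furan-3-yl on an aromatic carbon. For the measured compounds named here, no measured pair exchanges the furan for a pyridine, so nothing seen so far bears directly on this step; the one step measured concerns a different group and was small. With no reason to expect a shift beyond the scatter, the number for compound 3 in this assay is estimated to stay close to that of compound 1, a step of a 1.0-fold higher number from compound 1 to compound 3 (0.01 log units; within the scatter). The expected value for compound 3 is therefore 1700 nM, with a range from 700 nM to 4200 nM.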

Compound 3, half-maximal inhibitory concentration: > 50000 nM
Compound 3: a limit, no number; the forecaster's own chance of this, stated with the estimate: 5%; middle value at least 29-fold (1.46 log units) from the limit.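

In this assay, among the compounds shown here, pyridin-3-yl in place of furan-3-yl gives an at least 30-fold higher number from compound 1 to compound 3 (1.48 log units; beyond the scatter), so the group opposite the ring nitrogen can matter far more than the earlier compounds could show. Both groups are single aromatic rings with one hetero atom, the same hydrogen-bond donor and acceptor counts and no net charge, so these shared counts do not protect the number from changing at this position. The entry for compound 3 is a limit of the assay and not a number: the limit of > 50000 nM in this assay, at which 1 of the 3 values shown sits.

The compounds shown do not separate the change in ring size from the exchange of oxygen for nitrogen. A phenyl ring, six-membered with no nitrogen, and a thiophen-3-yl ring, five-membered with sulfur in place of oxygen, could help to tell these two changes apart.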